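A few compounds are considered here, and "the series" means these few. Any claim that something is new, unique, unknown or untested is made for them only; others in the source may bear on it.

Values in a functional assay on HepG2 cells (Homo sapiens) for cytotoxicity, read by MTT assay, with a stated time of 48 h (on this read-out higher numbers stand for weaker inhibition and lower numbers for stronger inhibition), exist for three compounds:

- compound 1 `O=C1/C(=C\c2ccc(O)cc2)S/C(=N/c2ccccc2)N1Cc1ccncc1` gives 11800 nM
- compound 2 `O=C1/C(=C\c2ccc(Cl)cc2)S/C(=N/c2ccccc2)N1Cc1ccncc1` gives 28800 nM
- compound 3 `O=C1/C(=C\c2ccc([N+](=O)[O-])cc2)S/C(=N/c2ccccc2)N1Cc1ccncc1` gives 18900 nM

Compound 3 stands within the scatter of both other compounds: a 1.5-fold lower number from compound 2 to compound 3 (0.18 log units; within the scatter) and a 1.6-fold higher number from compound 1 to compound 3 (0.20 log units; within the scatter) show no separation. Compound 4 `CN(C)c1ccc(/C=C2/S/C(=N/c3ccccc3)N(Cc3ccncc3)C2=O)cc1` differs from compound 3 by dimethylamino in place of nitro on an aromatic carbon, para to a large group (dimethylamino in place of nitro on an aromatic carbon). Among the measured compounds shown here, no measured compound carries dimethylamino, so the data offer no direct reading of this exchange. The nearest evidence is the three exchanges of one group for another on an aromatic carbon. Of these, only a 2.4-fold higher number from compound 1 to compound 2 (0.39 log units; beyond the scatter) passes the scatter, and it is modest. On that evidence from compound 2 and compound 1, no shift beyond the scatter is expected, in either direction. The expected change is small (a 1.2-fold lower number from compound 3 to compound 4 (0.07 log units; within the scatter)). In this assay compound 4 is estimated at 16000 nM (expected range 7000 nM to 36000 nM).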

Compound 4, half-maximal inhibitory concentration: 52600 nM
For compound 4 the middle estimate is 3.3-fold (0.52 log units) below the measured one, and the stated range ends below it.
By their numbers in this assay, from the lowest: compounds 1, 3, 2 and 4 (each within the scatter of the next, the first and the last beyond it).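

In this assay, the exchange of nitro for dimethylamino on this aromatic carbon, para to a large group, does register: a 2.8-fold higher number from compound 3 to compound 4 (0.44 log units; beyond the scatter) passes the scatter, and a 4.5-fold higher number from compound 1 to compound 4 (0.65 log units; beyond the scatter) is the widest step yet seen at this position, though still modest. Chloro and dimethylamino show no separation, with a 1.8-fold higher number from compound 2 to compound 4 (0.26 log units; within the scatter) staying within the scatter, so dimethylamino stands apart from hydroxy and nitro but not from chloro. Nothing at hand accounts for these steps.

The compounds shown carry only four groups at this position, so it remains open how a primary amine, a methoxy group or a carboxylic acid would read there. As far as these compounds go, whether these steps carry over to changes elsewhere on the shared core also stays open.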